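Side-chain exchange from compound 2 to compound 3

This account rests on a few compounds, and the source may have more. Where it says the series, first, only, none or still open, it means among the compounds named here.

In a functional assay on HT-29 cells (Homo sapiens) for inhibition, read by MTT assay, with a stated time of 120 h (on this read-out higher numbers stand for weaker inhibition and lower numbers for stronger inhibition), compound 1 (`CNC(=O)/C=C/c1ccc(NC(=O)Nc2ccc(Cl)c(C(F)(F)F)c2)cc1`) gives 11700 nM and compound 2 (`O=C(CCc1ccc(NC(=O)Nc2ccc(Cl)c(C(F)(F)F)c2)cc1)NC1CCC1`) gives 21300 nM. Going by the values given here, compound 2 therefore stands within the scatter of the only other number, and the two cannot be ranked. Compound 3 (`CNC(=O)/C=C(\C)c1ccc(NC(=O)Nc2ccc(Cl)c(C(F)(F)F)c2)cc1`) keeps the shared core and differs from compound 2 in one place: 1-methyl-2-(methylcarbamoyl)ethenyl in place of 2-(cyclobutylcarbamoyl)ethyl on an aromatic carbon.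

Among the compounds with values here, the one measured step bearing on this change is a 1.8-fold higher number from compound 1 to compound 2 (0.26 log units; within the scatter), which runs between the 2-(methylcarbamoyl)ethenyl and 2-(cyclobutylcarbamoyl)ethyl groups. Within the data shown here, the entering 1-methyl-2-(methylcarbamoyl)ethenyl carries the group of compound 1 with one added methyl, and no measured step isolates that methyl. The closest reference is therefore compound 1 at 11700 nM, with wide uncertainty around it. No step beyond the scatter is expected in this assay, and the estimated step is a 1.6-fold lower number from compound 2 to compound 3 (0.21 log units; within the scatter). For compound 3 the estimated value is 13000 nM, with an expected range of 5000 nM to 32000 nM.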

Compound 3, half-maximal inhibitory concentration: > 50000 nM
Compound 3: no number, only a limit; the forecaster's own chance of this, stated with the estimate: 10%; middle value at least 3.8-fold (0.58 log units) from the limit.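

Compound 3 carries no number in this assay, only a limit of the assay: the limit of > 50000 nM in this assay, at which 1 of the 3 values shown sits. Going by these compounds alone, the single added methyl of 1-methyl-2-(methylcarbamoyl)ethenyl, in place of 2-(methylcarbamoyl)ethenyl on an aromatic carbon para to a large group, gives an at least 4.2-fold higher number from compound 1 to compound 3 (0.63 log units; beyond the scatter), the first step from the group of compound 1 that lies beyond the scatter. The exchange against 2-(cyclobutylcarbamoyl)ethyl gives an at least 2.3-fold higher number from compound 2 to compound 3 (0.37 log units; beyond the scatter), whereas the larger difference in heavy atoms in a 1.8-fold higher number from compound 1 to compound 2 (0.26 log units; within the scatter) stays within the scatter, so among these compounds the reading at this position does not follow the heavy-atom count of the side chain, and a change as small as one methyl can carry a step beyond the scatter.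

From the compounds shown here alone, the upper end of both steps stays open, since only a limit stands for compound 3. Also open, going by these compounds, is whether the step belongs to the methyl as such or would recur with an ethyl on the same carbon, with the same methyl on the saturated chain of compound 2, or with a carboxylic acid in place of the methylcarbamoyl end.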